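This account rests on a few compounds, and the source may have more. Where it says the series, first, only, none or still open, it means among the compounds named here.

In a functional assay on HepG2 cells (Homo sapiens) for inhibition, read by fluorescence and resazurin assay, with a stated time of 72 h (on this read-out higher numbers stand for weaker inhibition and lower numbers for stronger inhibition), compound 1 `CN1CCN(S(=O)(=O)c2ccc(Nc3nccc(Nc4ccc5nc[nH]c5c4)n3)cc2)CC1` reaches only a limit, > 25000 nM. Compound 2 `O=C(Nc1ccccc1)Nc1cccc(Nc2nccc(Nc3ccc4nc[nH]c4c3)n2)c1` gives 11000 nM, and compound 3 `O=C(Nc1ccccc1)Nc1cccc(Nc2nccc(Nc3ccc4[nH]ccc4c3)n2)c1` gives 5000 nM, the lower of the two actual numbers. Compound 4 `Cc1c2ccc(Nc3ccnc(Nc4cccc(NC(=O)Nc5ccccc5)c4)n3)cc2nn1C` changes compound 3 on a nitrogen on an aromatic ring, where 2,3-dimethyl-2H-indazol-6-yl stands in place of 1H-indol-5-yl: 2,3-dimethyl-2H-indazol-6-yl in place of 1H-indol-5-yl on a nitrogen on an aromatic ring. Among the measured compounds shown here, one measured step bears on this place, a 2.2-fold lower number from compound 2 to compound 3 (0.34 log units; beyond the scatter), and it is modest though beyond the scatter. For the measured compounds named here, the entering group took no part in that step, so the step serves only as a guide to size. Going by the values given here, compound 3 also holds the lowest number so far, at 5000 nM, which leaves a move toward a higher number as the likelier direction. A step no larger than the measured one is therefore expected in this assay, and the estimate is a 1.6-fold higher number from compound 3 to compound 4 (0.20 log units; within the scatter). Compound 4 is expected at an estimated 8000 nM, within a range of 3000 nM to 20000 nM.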

Compound 4, half-maximal inhibitory concentration: 2400 nM
The estimate for compound 4 lay 3.3-fold (0.52 log units) above the measured number; the measured number lies below the stated range.
By their numbers in this assay, from the lowest: compound 4; then compound 3; then compound 2. At a limit, above all of these: compound 1.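

In this assay, replacing 1H-indol-5-yl with 2,3-dimethyl-2H-indazol-6-yl gives a 2.1-fold lower number from compound 3 to compound 4 (0.32 log units; beyond the scatter), so this place on the nitrogen can carry a number lower than any the earlier groups gave, even though the entering group has no hydrogen-bond donor and the leaving group has one. Set against 1H-benzimidazol-6-yl, the same group gives a 4.6-fold lower number from compound 2 to compound 4 (0.66 log units; beyond the scatter), so the three groups at this place now stand apart by steps that are all beyond the scatter. Nothing measured here accounts for the change.

The compounds shown do not separate the part played by the two methyl groups from that of the added ring nitrogen. Nor do they tell how a morpholine or a carboxylic acid would compare at this place.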